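This account rests on a few compounds, and the source may have more. Where it says the series, first, only, none or still open, it means among the compounds named here.

Compounds measured in an ADME assay on HEL cells (Homo sapiens) for cytotoxicity; on this read-out lower numbers stand for higher toxicity in this test and higher numbers for lower toxicity in this test:

compound 1 `CCCOC(=O)c1ccc(OCCCCCn2ccc(=O)[nH]c2=O)cc1` — > 100000 nM
compound 2 `O=c1ccn(CCCCCOc2ccc(Cl)cc2)c(=O)[nH]1` — "not determined" (no result reported)
compound 3 `O=C(O)c1ccc(OCCCCCn2ccc(=O)[nH]c2=O)cc1` — "not determined" (no result reported)

In this assay compound 1 reached only a limit, > 100000 nM, which is the edge of what the test reports and not a number. For compound 2 the read-out is given as "not determined" (no result reported), and for compound 3 it is likewise "not determined" (no result reported). Compound 2 therefore stands without a number of its own: of the three values shown, one is a limit and the other is, like its own, an entry without a result, so the limit of > 100000 nM in this assay, at which 1 of the 3 values shown sits, is the only measured anchor in the set.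

The step under consideration leads from compound 2 to compound 4 `Cc1cccc(OCCCCCn2ccc(=O)[nH]c2=O)c1`. The change is 3-methylphenyl in place of 4-chlorophenyl on an oxygen on a saturated carbon. Among the measured compounds shown here, since no step between measured compounds is known in this assay, the author expects no shift beyond the usual scatter for this change, and expects compound 4 to behave much like compound 1, which reached > 100000 nM. Compound 4 is estimated at 100000 nM, within a range from 30000 nM to 300000 nM, with a good chance that only a limit will be reported.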

Compound 4, half-maximal cytotoxic concentration: > 100000 nM
Compound 4: a limit, no number (the forecaster's own chance of this, stated with the estimate: 70%); the middle value lies on the limit itself.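

In this assay compound 4 reached only a limit, > 100000 nM. Among the compounds shown here, compound 2 stands without a number, so no step from it to compound 4 can be read. The compounds shown leave open whether 3-methylphenyl in place of 4-chlorophenyl changes the half-maximal cytotoxic concentration at all.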